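Small chain or aromatic group on the chain carbon

The source may hold more compounds than are shown below. What is called first, only, known or untested is meant among the compounds shown, and "the series" means these compounds.

In a functional assay on RAW264.7 cells (Mus musculus) for inhibition, read by Griess assay, with stated times of 2 h and 24 h (a lower number here means a stronger inhibitor, a higher number a weaker inhibitor), compound 2 `COc1ccc([C@@H]2CC(=O)c3c(O)cc(OCc4cn(Cc5ccccc5C(F)(F)F)nn4)cc3O2)cc1O` gives 12500 nM, within the scatter of compound 3 `COc1ccc([C@@H]2C/C(=N\O)c3c(O)cc(OCc4cn(Cc5ccccc5C)nn4)cc3O2)cc1O` at 18000 nM, while compound 1 `CCn1cc(COc2cc(O)c3c(c2)O[C@H](c2ccc(OC)c(O)c2)C/C3=N\O)nn1` reads 3140 nM. Compound 4 `C=CCn1cc(COc2cc(O)c3c(c2)O[C@H](c2ccc(OC)c(O)c2)CC3=O)nn1` differs from compound 2 by vinyl in place of 2-(trifluoromethyl)phenyl on a saturated chain carbon bound to an aromatic nitrogen. Within the data shown here, the only measured step bearing on this is a 5.7-fold higher number from compound 1 to compound 3 (0.76 log units; beyond the scatter), with 2-methylphenyl in place of methyl at that place, on a core that is not the core of compound 2. The reverse direction, towards a lower number of similar or somewhat smaller size, is therefore expected in this assay. The expected change is a 3.1-fold lower number from compound 2 to compound 4 (0.49 log units; beyond the scatter). Compound 4 is estimated at 4000 nM, with an expected range of 1500 nM to 11000 nM.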

Compound 4, half-maximal inhibitory concentration: 13800 nM
Estimate against measurement, compound 4: 3.5-fold (0.54 log units) below; measured number above the stated range.
By their numbers in this assay, from the lowest: compound 1; then compounds 2, 4 and 3 (each within the scatter of the next).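

In this assay, exchanging 2-(trifluoromethyl)benzyl for allyl on the shared core gives a 1.1-fold higher number from compound 2 to compound 4 (0.04 log units; within the scatter), so on this core the number does not respond to this change at this place. The earlier step, a 5.7-fold higher number from compound 1 to compound 3 (0.76 log units; beyond the scatter), therefore does not carry over to the core of compound 2, although the groups exchanged there also differ. No measured evidence bears on this result.

Open, on these data alone, is how an amine or a carboxylic acid on a longer chain would read at this place. Also open, as far as these compounds go, is whether allyl on the core of compound 1 would track methyl.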